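Replacing the fluorophenyl amide of compound 2 with thiophene

The compounds below may be only part of what the source reports. "The series", "measured", "known", "first", "only" and "open" are said of these compounds alone.

Compound 2, with the structure `CC(C)OC(=O)C1=CN(C(=O)c2ccc(F)cc2)CC(C)(C)c2cc(C#N)[nH]c21`, is measured in an assay on HEK293 cells for agonist activity at Bile acid receptor (Homo sapiens), read by a luciferase reporter (a lower number here means a smaller maximal response, a higher number a larger maximal response), where compound 2 gives 119%. Two related compounds share its core. Compound 3, `CC(C)OC(=O)C1CN(C(=O)C2CCOCC2)CC(C)(C)c2cc(C#N)[nH]c21`, gives 112% in this assay, a difference from compound 2 that lies within the usual scatter. Compound 1, `CC(C)OC(=O)C1CN(C(=O)c2ccc(F)cc2)CC(C)(C)c2cc(C#N)[nH]c21`, gives 85% in this assay, a number that sits beyond the scatter below compound 2.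

The new compound 4 has the structure `CC(C)OC(=O)C1=CN(C(=O)c2cccs2)CC(C)(C)c2cc(C#N)[nH]c21`. Its difference from compound 2 is thiophen-2-yl in place of 4-fluorophenyl on a carbonyl carbon.

For the measured compounds named here, only one measured step touches the same position. Between compound 1 and compound 3 the same 4-fluorophenyl group on the carbonyl carbon was exchanged, there for oxan-4-yl, and the response rose: a number 27 percentage points higher from compound 1 to compound 3 (beyond the scatter). That exchange shows that the group on this carbonyl carbon can move the maximal response by a modest amount, but the entering group there was not thiophen-2-yl, and compound 2 already gives the largest number among the three. A change no larger than the scatter, in either direction, is therefore expected from compound 2 to compound 4: a number 7 percentage points lower from compound 2 to compound 4 (within the scatter).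

Compound 4 is estimated to give 112% in this assay, most likely between 92% and 132%.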

Compound 4, largest response reached (reported as efficacy), in percent of the reference or control that the assay uses: 114%
For compound 4 the middle estimate is 2 percentage points below the measured one, and the stated range covers the measured number.
By their numbers in this assay, from the lowest: compound 1; then compounds 3, 4 and 2 (each within the scatter of the next).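

In this assay, the exchange of 4-fluorophenyl for thiophen-2-yl on the carbonyl carbon gives a number 5 percentage points lower from compound 2 to compound 4 (within the scatter), so this pair shows no shift that can be told apart from repeat-measurement noise. For the compounds shown here, the only earlier step at this carbonyl carbon brought in a non-aromatic oxan-4-yl group, whereas this one shows that, on the core of compound 2, a five-membered aromatic ring with a sulfur atom can take the place of a six-membered aromatic ring of carbon only while the maximal response stays within the scatter. The fluorine of the leaving group is therefore not needed to hold the response in this pair, although no measurement available here explains why the two groups behave alike.

On these data alone, it remains open whether thiophen-2-yl would behave the same way on the core of compound 1, where the earlier exchange gave a number 27 percentage points higher from compound 1 to compound 3 (beyond the scatter) and so moved the response beyond the scatter. Also unresolved is how the response would change with a group of another kind on this carbonyl carbon, such as an aminomethyl group, a carboxylic acid or a longer alkyl chain.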